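A few compounds are considered here, and "the series" means these few. Any claim that something is new, unique, unknown or untested is made for them only; others in the source may bear on it.

Compound 1 `O=C(CCCCCCc1ccccn1)c1ncc(-c2ccccn2)o1` gives 120 nM in an assay for inhibition of Fatty-acid amide hydrolase 1 (Rattus norvegicus); on this read-out lower numbers stand for stronger inhibition and higher numbers for weaker inhibition. Compound 2 `O=C(O)c1ccc(CCCCCCC(=O)c2ncc(-c3ccccn3)o2)cc1` reaches only a limit of this assay, > 600 nM. Compound 3 `O=C(CCCCCCc1cccc(Cl)c1Cl)c1ncc(-c2ccccn2)o1` gives 0.9 nM.

Compound 3 holds the lowest number of the two actual values, with compound 1 nearest at a 130-fold lower number from compound 1 to compound 3 (2.12 log units; beyond the scatter). Compound 4 `Nc1cccc(CCCCCCC(=O)c2ncc(-c3ccccn3)o2)c1` differs from it by 3-aminophenyl in place of 2,3-dichlorophenyl on a saturated chain carbon, six bonds along the chain from a carbonyl carbon. The bearing steps run the other way: a 130-fold lower number from compound 1 to compound 3 (2.12 log units; beyond the scatter) and an at least 660-fold lower number from compound 2 to compound 3 (2.82 log units; beyond the scatter), both from a heteroaryl or carboxyl-bearing ring to the 2,3-dichlorophenyl. Undoing the dichlorophenyl for a 3-aminophenyl is therefore expected to raise the number considerably, by about a 67-fold higher number from compound 3 to compound 4 (1.82 log units; beyond the scatter). Compound 4 is estimated at 60 nM, between 10 nM and 400 nM.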

Compound 4, inhibition constant: 30 nM
Compound 4: middle estimate off by 2.0-fold (0.30 log units), on the high side; low and high end bracket the measured number.
By their numbers in this assay, from the lowest: compound 3; then compound 4; then compound 1. At a limit, above all of these: compound 2.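

Putting 3-aminophenyl in place of pyridin-2-yl gives a 4.0-fold lower number from compound 1 to compound 4 (0.60 log units; beyond the scatter), so a carbon-only aromatic ring at this position improves on compound 1 even without chlorine. The 2,3-dichlorophenyl nevertheless keeps a large lead, with a 33-fold higher number from compound 3 to compound 4 (1.52 log units; beyond the scatter). Replacing 4-carboxyphenyl with 3-aminophenyl gives an at least 20-fold lower number from compound 2 to compound 4 (1.30 log units; beyond the scatter), a step read against a limit of the assay: the limit of > 600 nM in this assay, at which 1 of the 4 values shown sits.

A plain phenyl would show whether the amine itself helps or hinders. A 3-chlorophenyl and a 4-aminophenyl would separate the effect of the group from that of its ring position.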